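Pyridin-4-yl for 4-methoxyphenyl: compound 3 to compound 4

This account rests on a few compounds, and the source may have more. Where it says the series, first, only, none or still open, it means among the compounds named here.

Measured so far:
compound 1, `CC(C)C[C@H](N)CN(C(=O)C(C)Cc1ccccc1)c1ccc(-c2ccccc2)cc1`, 1.2 nM
compound 2, `CC[C@@H](C)[C@H](N)CN(C(=O)[C@@H]1C[C@H]1c1ccccc1)c1ccc(-c2ccccc2)cc1`, 1.4 nM
compound 3, `CC[C@H](C)[C@H](N)CN(C(=O)[C@@H]1C[C@H]1c1ccc(OC)cc1)c1ccc(-c2ccccc2)cc1`, > 25000 nM

In a functional assay for agonist activity at G protein-coupled receptor 88 (Homo sapiens), read by HTRF and cAMP accumulation (on this read-out higher numbers stand for an effect only at larger amounts of compound and lower numbers for an effect already at smaller amounts), compound 1 gives 1.2 nM and compound 2 gives 1.4 nM; these two values are within the usual scatter of each other. Among the compounds with values here, compound 3 differs from compound 2 in more than one place, so no single step connects them. In this assay compound 3 reports only a limit, > 25000 nM, and so stands at the limit of > 25000 nM in this assay, at which 1 of the 3 values shown sits, the top end of the numbers seen here.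

Compound 4, `CC[C@H](C)[C@H](N)CN(C(=O)[C@@H]1C[C@H]1c1ccncc1)c1ccc(-c2ccccc2)cc1`, carries the change (pyridin-4-yl in place of 4-methoxyphenyl on a saturated ring carbon). Within the data shown here, no measured step covers this exchange, so the expected step of an at least 1.2-fold lower number from compound 3 to compound 4 (0.09 log units; that floor lies within the scatter) is only a guess, most likely none beyond the scatter with a further limit the probable outcome. Compound 4 is therefore estimated at 20000 nM, in the range 1000 nM to 60000 nM.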

Compound 4, half-maximal effective concentration: 1500 nM
Compound 4: the middle estimate sits 13-fold (1.12 log units) above what was measured, within the range that was stated.
By their numbers in this assay, from the lowest: compounds 1 and 2 (each within the scatter of the next); then compound 4. At a limit, above all of these: compound 3.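

In this assay, the group on this saturated ring carbon of the cyclopropyl ring strongly affects the read-out: pyridin-4-yl in place of 4-methoxyphenyl gives an at least 16-fold lower number from compound 3 to compound 4 (1.22 log units; beyond the scatter). This step is a floor, since compound 3 stands at a limit of the assay: the limit of > 25000 nM in this assay, at which 1 of the 4 values shown sits.

One aromatic ring exchanged for another at this place is thus enough to turn a limit into a measured number. Still open, as far as these compounds go, is how pyridin-3-yl would read at this place. Also open, from the compounds shown here alone, is whether a 4-aminophenyl or 4-carboxyphenyl group would follow 4-methoxyphenyl or pyridin-4-yl.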